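Swapping trifluoromethyl for fluoro on an azido compound

This account rests on a few compounds, and the source may have more. Where it says the series, first, only, none or still open, it means among the compounds named here.

Compound 1 `N[C@H]1C[C@H](n2ccc(=O)[nH]c2=O)O[C@@H]1CO`: 50 uM
Compound 2 `N[C@@H]1C[C@H](n2cc(F)c(=O)[nH]c2=O)O[C@@H]1CO`: 1 uM
Compound 3 `[N-]=[N+]=N[C@H]1C[C@H](n2cc(C(F)(F)F)c(=O)[nH]c2=O)O[C@@H]1CO`: 100 uM

These three compounds were tested in a functional assay on Sarcoma-180 cells (Mus musculus) for inhibition; on this read-out higher numbers stand for an effect only at larger amounts of compound and lower numbers for an effect already at smaller amounts. There, compound 3 gives 100 uM. That value lies within the usual scatter of compound 1, so the two cannot be told apart, while compound 2 sits far lower, well beyond the scatter of compound 3.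

The next compound to be tested is compound 4 `[N-]=[N+]=N[C@H]1C[C@H](n2cc(F)c(=O)[nH]c2=O)O[C@@H]1CO`. It differs from compound 3 in a single place, with fluoro in place of trifluoromethyl on an aromatic carbon.

For the measured compounds named here, no two measured compounds differ in one place only, so the data give no direct measure of this change. Going by the values given here, the only hint comes from compound 2, which carries the same fluoro group and gives 1 uM. However, compound 2 also differs from compound 4 elsewhere, so only part of that gap can be expected to carry over. In this assay a moderate move toward a lower number is therefore expected, beyond the scatter but short of the full gap. This expectation amounts to an estimated step of a 10-fold lower number from compound 3 to compound 4 (1.00 log units; beyond the scatter).

For compound 4 the estimated value is 10 uM, with an expected range from 1.5 uM to 60 uM.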

Compound 4, concentration for half-maximal effect: 40 uM
Beside the measured number, compound 4's estimate is 4.0-fold (0.60 log units) below it, within the range that was stated.
By their numbers in this assay, from the lowest: compound 2; then compounds 4, 1 and 3 (each within the scatter of the next, the first and the last beyond it).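

For the compounds shown here, this is the first pair in the set that differs in one place only, so the effect of the change can now be read directly. In this assay, putting fluoro in place of trifluoromethyl on the aromatic carbon, with the azido group and the rest of the shared core unchanged, gives a 2.5-fold lower number from compound 3 to compound 4 (0.40 log units; beyond the scatter). The group on this carbon therefore does matter to the read-out, although the step is modest, and the compounds shown offer no independent measurement that would explain why it occurs.

Going by these compounds alone, one pair gives only one step, so it cannot show whether the read-out follows group size or some other feature, and a methyl group or a chloro group on this same aromatic carbon would help to separate those possibilities. As far as these compounds go, it also remains open whether the same swap would give a step of similar size on a compound that carries an amine instead of the azido group.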